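Cyclohexyl versus oxolanyl on a propyl-bearing adenosine ligand

The compounds below may be only part of what the source reports. "The series", "measured", "known", "first", "only" and "open" are said of these compounds alone.

The measured compounds and their values:

Compound 1 `CCn1c(-c2ccccc2)nc2c(NC3CCCCC3)ncnc21`: 10 nM
Compound 2 `CCCn1c(-c2ccccc2)nc2c(NC3CCOC3)ncnc21`: 25 nM
Compound 3 `CCn1c(-c2ccccc2)nc2c(NC3CCOC3)ncnc21`: 10 nM

The study concerns a small set of analogues that share one core and differ at two places. In an assay on CHO cells for displacement of a labelled ligand from adenosine receptor A1 (Homo sapiens), read by scintillation counting, with a stated time of 3 h (a higher number here means a weaker inhibitor, a lower number a stronger inhibitor), compound 1 gives 10 nM, compound 3 gives 10 nM, and compound 2 gives 25 nM, which is the highest of the three numbers.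

Two measured steps are known. The difference between compound 3 and compound 1 is cyclohexyl in place of oxolan-3-yl on a nitrogen on an aromatic ring, and this step gave no change at the digits printed from compound 3 to compound 1 (within the scatter). The difference between compound 3 and compound 2 is methyl in place of hydrogen on a saturated chain carbon, two bonds along the chain from an aromatic nitrogen, and that step gave a 2.5-fold lower number from compound 2 to compound 3 (0.40 log units; beyond the scatter).

Compound 4 `CCCn1c(-c2ccccc2)nc2c(NC3CCCCC3)ncnc21` has not yet been measured. It differs from compound 2 by cyclohexyl in place of oxolan-3-yl on a nitrogen on an aromatic ring. Going by the values given here, this is the same change as the one from compound 3 to compound 1; the two place descriptions read alike word for word. The two cores on which it is made differ only by the methyl in place of hydrogen already described.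

For compound 4 in this assay the expected step is no change at the digits printed from compound 2 to compound 4 (within the scatter), beside the earlier measured one, because no change at the digits printed from compound 3 to compound 1 (within the scatter) showed that exchange leaving the number unmoved. The estimate for compound 4 is therefore 25 nM, expected to fall between 12 nM and 50 nM.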

Compound 4, inhibition constant: 27 nM
Beside the measured number, compound 4's estimate is 1.1-fold (0.03 log units) below it; measured number inside the range.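

In this assay, the exchange of oxolan-3-yl for cyclohexyl on a nitrogen on an aromatic ring gave a 1.1-fold higher number from compound 2 to compound 4 (0.03 log units; within the scatter), and this agrees with the same exchange on the other core: the same change on two cores in this assay, no change at the digits printed (within the scatter) from compound 3 to compound 1 and a 1.1-fold higher number (0.03 log units; within the scatter) from compound 2 to compound 4, 1.1-fold (0.03 log units) apart, within the scatter of two such steps. The second change, methyl in place of hydrogen on a saturated chain carbon, two bonds along the chain from an aromatic nitrogen, gave a 2.7-fold higher number from compound 1 to compound 4 (0.43 log units; beyond the scatter), and it also agrees with its earlier counterpart: the same change on two cores in this assay, a 2.5-fold lower number (0.40 log units; beyond the scatter) from compound 2 to compound 3 and a 2.7-fold lower number (0.43 log units; beyond the scatter) from compound 4 to compound 1, 1.1-fold (0.03 log units) apart, within the scatter of two such steps. Across these four compounds, each change therefore carried over from one core to the other, but this rests on a single pair of cores in a single assay, and the ring exchange stayed within the scatter on both, so the agreement does not show that either step would hold on other cores or with other groups.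

The compounds shown leave open whether a longer chain, such as butyl, at the same place would move the number further in the same direction. They also leave open whether a ring carrying an amine, such as piperidin-4-yl, would match cyclohexyl and oxolan-3-yl on that nitrogen on either core.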